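Carbamate in place of acetate on a shared core

A few compounds are considered here, and "the series" means these few. Any claim that something is new, unique, unknown or untested is made for them only; others in the source may bear on it.

Of the compounds shown here, three sharing one core have been measured in a functional assay (trachea) with Rattus norvegicus as the target; a higher number here means a more potent compound, by a factor of ten per unit of this negative logarithm, a lower number a less potent compound. Compound 1 `CCC(=O)c1ccc2c(c1)C(n1ccccc1=O)=CC(C)(C)O2` gives 5.85, and compound 2 `CC1(C)C=C(n2ccccc2=O)c2cc(C(=O)c3ccc(O)cc3)ccc2O1` gives 5.87; the step of a number 0.02 log units higher from compound 1 to compound 2 (within the scatter) shows that 4-hydroxyphenyl in place of ethyl on a carbonyl carbon changes nothing of note. Compound 3 `CC(=O)Oc1ccc2c(c1)C(n1ccccc1=O)=CC(C)(C)O2` gives 4.97, the lowest of the three numbers: the steps of a number 0.88 log units lower from compound 1 to compound 3 (beyond the scatter) and a number 0.90 log units lower from compound 2 to compound 3 (beyond the scatter) both show that acetoxy on the aromatic carbon is worth less than either carbonyl group it replaces.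

Compound 4 `CC1(C)C=C(n2ccccc2=O)c2cc(OC(=O)Nc3ccc(F)cc3)ccc2O1` is the next compound, not yet measured. It differs from compound 3 in one place: (4-fluorophenyl)amino in place of methyl on a carbonyl carbon. Going by the values given here, no measured step covers this exact change. The nearest guide is the step from compound 1 to compound 2, where a larger aromatic group on a carbonyl carbon left the number where it was; by that analogy, and with no other evidence, only a small step is expected, a number 0.33 log units higher from compound 3 to compound 4 (beyond the scatter), with a wide range in either direction. Compound 4 is therefore estimated at 5.3, between 4.5 and 6.1.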

Compound 4, logarithm of the reciprocal of the active concentration, log(1/C): 4.37
Compound 4: middle estimate off by 0.93 log units, on the high side; measured number below the stated range.
By their numbers in this assay, from the lowest: compound 4; then compound 3; then compounds 1 and 2 (each within the scatter of the next).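

In this assay, (4-fluorophenyl)amino in place of methyl on a carbonyl carbon whose other neighbour is the oxygen of the acetoxy group lowers the number, a number 0.60 log units lower from compound 3 to compound 4 (beyond the scatter), so this larger group is not neutral at this carbonyl carbon. The earlier exchange on a carbonyl carbon, 4-hydroxyphenyl in place of ethyl, gave a number 0.02 log units higher from compound 1 to compound 2 (within the scatter), which shows that the flat result seen there does not extend to every large aromatic group on every carbonyl carbon of this series, although the two changes differ both in the entering group and in what else the carbonyl carbon carries. Nothing available here accounts for the difference between these two steps.

Going by these compounds, a single step cannot separate the contributions of the amino hydrogen, the aromatic ring and the fluorine, so it remains open whether an unsubstituted phenylamino group or a dimethylamino group on the same carbonyl carbon would give a similar number. On these data alone, it is equally open whether a simple longer chain, such as propyl in place of methyl, would lower the number as well.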